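A few compounds are considered here, and "the series" means these few. Any claim that something is new, unique, unknown or untested is made for them only; others in the source may bear on it.

Working notes on the series. Compound 1 `Cc1ccc(Cn2c(Cl)nc3cc(Cl)c(Cl)cc32)cc1` carries a methyl group on the benzyl ring, and compound 2 `FC(F)(F)c1ccc(Cn2c(Cl)nc3cc(Cl)c(Cl)cc32)cc1` the trifluoromethyl analogue of it. In a functional assay on CEM-SS cells (Homo sapiens) for cytotoxicity (on this read-out higher numbers stand for weaker inhibition and lower numbers for stronger inhibition), compound 1 gives a value that is a limit of the assay, > 100000 nM. In this assay compound 2 likewise gives only a limit, > 100000 nM. The change trifluoromethyl in place of methyl on an aromatic carbon therefore gives a step that the two limits leave unreadable from compound 1 to compound 2. Compound 3 `Cc1cccc(Cn2c(Cl)nc3cc(Cl)c(Cl)cc32)c1` shares the atoms of compound 1 joined differently; the difference between the two cores is not broken down here. In this assay compound 3 gives only a limit, > 100000 nM. Compound 4 `FC(F)(F)c1cccc(Cn2c(Cl)nc3cc(Cl)c(Cl)cc32)c1` follows from compound 3 by trifluoromethyl in place of methyl on an aromatic carbon; this is the same kind of change as from compound 1 to compound 2, the place differing in that the group sits meta rather than para to a large group. Because the limit of > 100000 nM in this assay, at which 3 of the 3 values shown sit, is where all three measured values sit, the expected step that the limit leaves unreadable from compound 3 to compound 4 is small and compound 4 is estimated at 150000 nM, most likely again reported as a limit.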

Compound 4, half-maximal inhibitory concentration: > 100000 nM
Compound 4 gave a limit, no number (the forecaster's own chance of this, stated with the estimate: 85%); the middle value lies beyond the limit too.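

Compound 3 and compound 4 both stand only as limits in this assay, so no step can be read between them: the limit of > 100000 nM in this assay, at which 4 of the 4 values shown sit. The compounds shown leave open whether trifluoromethyl in place of methyl changes the read-out at all.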